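This account rests on a few compounds, and the source may have more. Where it says the series, first, only, none or still open, it means among the compounds named here.

Measured so far:
compound 1, `CCCCCCOc1ccc2c(Cl)ccnc2c1`: 2660 nM
compound 2, `CCCCCCOc1ccc2c(NCCN(C)C)ccnc2c1`: 1870 nM

In a functional assay on DLD-1 cells (Homo sapiens) for cytotoxicity, read by MTT assay, with a stated time of 48 h (on this read-out higher numbers stand for weaker inhibition and lower numbers for stronger inhibition), compound 1 gives 2660 nM, the higher of the two numbers shown, and compound 2 gives 1870 nM; the step of a 1.4-fold lower number from compound 1 to compound 2 (0.15 log units; within the scatter) lies within the scatter. Compound 3, `CC(C)Oc1ccc2c(Cl)ccnc2c1`, differs from compound 1 by isopropyl in place of hexyl on an oxygen on an aromatic ring. Among the measured compounds shown here, no measured step touches that oxygen-bound chain; the only step known concerns a different place, so it gives no guide to direction or size. The step from compound 1 to compound 3 is therefore expected to be a 2.3-fold higher number from compound 1 to compound 3 (0.35 log units; beyond the scatter), leaning toward weaker inhibition. Compound 3 is estimated at 6000 nM, between 2000 nM and 20000 nM.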

Compound 3, half-maximal inhibitory concentration: 3240 nM
Compound 3: the middle estimate sits 1.9-fold (0.27 log units) above what was measured; the range from low to high includes it.
By their numbers in this assay, from the lowest: compounds 2, 1 and 3 (each within the scatter of the next).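

In this assay, replacing hexyl with isopropyl on the oxygen gives a 1.2-fold higher number from compound 1 to compound 3 (0.09 log units; within the scatter) and so stays within the usual scatter. Among the compounds shown here, this is the first look at this position: the oxygen-bound chain can go from 6 heavy atoms to 3 with no clear change in the number. Nothing available explains this result. Still open, on these data alone, is whether a longer chain such as octyl, or a chain ending in an amine, would shift the number on that oxygen. Also open, as far as these compounds go, is how isopropyl behaves alongside the (2-(dimethylamino)ethyl)amino group of compound 2.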